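From benzyl to 4-propylphenyl on a shared core

The source may hold more compounds than are shown below. What is called first, only, known or untested is meant among the compounds shown, and "the series" means these compounds.

- compound 1 `O=C1C(Nc2ccc(I)cc2)=CC(=O)c2c1nc1n2[C@H]2OC[C@@H](O)[C@H]2OC1` gives 2530 nM
- compound 2 `Cc1ccc(NC2=CC(=O)c3c(nc4n3[C@H]3OC[C@@H](O)[C@H]3OC4)C2=O)cc1` gives > 4000 nM
- compound 3 `O=C1C(NCc2ccccc2)=CC(=O)c2c1nc1n2[C@H]2OC[C@@H](O)[C@H]2OC1` gives > 8000 nM

These results come from a functional assay on ECa-109 cells for inhibition, with ECa-109 cell line (Homo sapiens) as the target, read by sulforhodamine B assay; on this read-out higher numbers stand for weaker inhibition and lower numbers for stronger inhibition. Compound 2 gives only a limit, > 4000 nM, and not a number. As far as these compounds go, compound 3 also gives only a limit, > 8000 nM, so its true position is unknown. The next compound, compound 4 `CCCc1ccc(NC2=CC(=O)c3c(nc4n3[C@H]3OC[C@@H](O)[C@H]3OC4)C2=O)cc1`, has not been measured. It differs from compound 3 by 4-propylphenyl in place of benzyl on an amine nitrogen.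

Among the compounds with values here, three measured steps bear on this change. Benzyl in place of 4-iodophenyl gave an at least 3.1-fold higher number from compound 1 to compound 3 (0.49 log units; beyond the scatter), the closest precedent, though it runs the opposite way. Methyl in place of iodo gave an at least 1.5-fold higher number from compound 1 to compound 2 (0.19 log units; that floor lies within the scatter), so only a floor can be read. Benzyl in place of 4-methylphenyl gave a step that the two limits leave unreadable from compound 2 to compound 3, which adds no size.

Compound 4 carries a substituted phenyl on that nitrogen, as compound 1 does, so a modest move to a lower number is expected in this assay. The expected change is an at least 2.2-fold lower number from compound 3 to compound 4 (0.35 log units; beyond the scatter), which would mean stronger inhibition. For compound 4 the estimated value is 3500 nM (expected range 1300 nM to 9000 nM), although the measurement could still return only a limit.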

Compound 4, half-maximal inhibitory concentration: > 4000 nM
Compound 4: only a limit was reported; the forecaster's own chance of this, stated with the estimate: 40%; at least 1.1-fold (0.05 log units) between middle value and limit.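

Compound 4 is the second case, after compound 2, where a phenyl group carrying a carbon chain on the amine nitrogen returns a limit and not a number, so the only measured number among the compounds shown still belongs to compound 1, with its 4-iodophenyl. In this assay, propyl in place of iodo gives an at least 1.5-fold higher number from compound 1 to compound 4 (0.19 log units; that floor lies within the scatter), so this floor alone does not establish a real loss of inhibition. The steps linking compound 4 to compound 3 and to compound 2 cannot be read, with limits at both ends and the comparison stopped at this level: the limit of > 4000 nM in this assay, at which 2 of the 4 values shown sit.

The compounds shown leave open whether iodo itself matters, or whether another halogen such as chloro or bromo in its place would also give a measured number. They also leave open how a longer chain or an amine on the phenyl would read, and how far compound 2 and compound 4 actually lie past their limit.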